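Moving one hydroxyl group at the limit of the assay

A few compounds are considered here, and "the series" means these few. Any claim that something is new, unique, unknown or untested is made for them only; others in the source may bear on it.

In a functional assay, with a stated time of 30 min (on this read-out higher numbers stand for weaker inhibition and lower numbers for stronger inhibition), compound 1 `Cc1cccc(/C=N/c2ccc(OCc3ccccc3)cc2)c1O` gives > 200000 nM, which is a limit of the assay and not a number. Compound 2 `COc1cccc(/C=N/c2ccc(OCc3ccccc3)cc2)c1O` gives > 200000 nM in this assay, again a limit rather than a number. Compound 3 `Oc1ccc(/C=N/c2ccc(OCc3ccccc3)cc2)c(O)c1` gives > 200000 nM in this assay, also a limit. The step that the two limits leave unreadable from compound 1 to compound 2 and the step that the two limits leave unreadable from compound 1 to compound 3 are both unreadable, since all three values sit at the limit of > 200000 nM in this assay, at which 3 of the 3 values shown sit. Compound 3 thus stands at the same limit as the other two, with no number to place it higher or lower.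

Compound 4 `Oc1cccc(/C=N/c2ccc(OCc3ccccc3)cc2)c1O` differs from compound 3 in one place: 2,3-dihydroxyphenyl in place of 2,4-dihydroxyphenyl on a carbon with a double bond to nitrogen. No measured step bears on this change beyond the two unreadable ones, and with every shown value at the limit of > 200000 nM in this assay, at which 3 of the 3 values shown sit, no direction can be drawn from them. Compound 4 is therefore expected to remain at the same limit, with an estimated value of 200000 nM and a range from 100000 nM to 1000000 nM. The step of a number no higher from compound 3 to compound 4 (the limit leaves the size open) that this estimate means is expected to be none beyond the scatter.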

Compound 4, half-maximal inhibitory concentration: 13300 nM
The estimate for compound 4 lay 15-fold (1.18 log units) above the measured number, and the stated range ends above it.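

In this assay, among these compounds, compound 4 gives the only readable number so far, and moving one hydroxyl group, with the same atoms joined differently, accounts for an at least 15-fold lower number from compound 3 to compound 4 (1.17 log units; beyond the scatter). Replacing the methyl group with a hydroxy group gives an at least 15-fold lower number from compound 1 to compound 4 (1.17 log units; beyond the scatter), and hydrogen in place of methyl on an oxygen on an aromatic ring gives an at least 15-fold lower number from compound 2 to compound 4 (1.17 log units; beyond the scatter). Among these compounds, a number appears only with the 2,3-dihydroxyphenyl group, while the other three stay at a limit of the assay: the limit of > 200000 nM in this assay, at which 3 of the 4 values shown sit.

Going by these compounds, the full size of these steps stays open, as compound 1, compound 2 and compound 3 give only limits. Also open, on these data alone, is whether an amine or a carboxylic acid in place of either hydroxy group of compound 4 would keep a number in this assay.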